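The compounds below may be only part of what the source reports. "The series", "measured", "known", "first", "only" and "open" are said of these compounds alone.

Measured in a functional assay on NCI-H322M cells (Homo sapiens) for inhibition, read by sulforhodamine B assay, with a stated time of 48 h, tested at 10 uM; a higher number here means more inhibition at the concentration tested (going by the name of the read-out), a lower number less inhibition:

compound 1 `c1ccc(-c2cn3ccnc3c(-c3ccc4ncn(C5CCCCC5)c4c3)n2)cc1`: 5.25%
compound 2 `O=Cc1ccc(-c2cn3ccnc3c(-c3ccc4ncn(C5CCCCC5)c4c3)n2)cc1`: 11.2%
compound 3 `Fc1ccc(-c2cn3ccnc3c(-c3ccc4ncn(C5CCCCC5)c4c3)n2)cc1`: 0.01%

Compound 3 holds the smallest of the three numbers in this assay, but the spread is narrow: a number 5.2 percentage points lower from compound 1 to compound 3 (within the scatter), whereas a number 11.2 percentage points lower from compound 2 to compound 3 (beyond the scatter). Only the gap to compound 2 counts as a real difference, and all three compounds sit near the floor of the read-out.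

Compound 4 `Brc1ccc(-c2cn3ccnc3c(-c3ccc4ncn(C5CCCCC5)c4c3)n2)cc1` differs from compound 3 at a single point: bromo in place of fluoro on an aromatic carbon.

Among the measured compounds shown here, no measured step exchanges one halogen for another. The two steps that touch this position both concern the fluoro of compound 3 (a number 5.2 percentage points lower from compound 1 to compound 3 (within the scatter), a number 11.2 percentage points lower from compound 2 to compound 3 (beyond the scatter)), and neither moves the read-out far. A swap of fluoro for bromo at the same position is therefore expected to give at most a small shift, in no certain direction, with the number staying close to the floor. The estimate for compound 4 is 4%, range -8% to 16%, which corresponds to an expected step of a number 4 percentage points higher from compound 3 to compound 4 (within the scatter) and falls within the scatter.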

Compound 4, a percentage reported as inhibition, at one concentration (the size of the read-out at that concentration, not a potency): 4.21%
Estimate against measurement, compound 4: 0.2 percentage points below, within the range that was stated.
By their numbers in this assay, from the lowest: compounds 3, 4, 1 and 2 (each within the scatter of the next, the first and the last beyond it).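

In this assay, among the compounds shown here, the 4-fluorophenyl to 4-bromophenyl exchange gives the first direct comparison of two halogens at this position, and a number 4.2 percentage points higher from compound 3 to compound 4 (within the scatter) does not separate them. Bromo is equally inseparable from the other two groups, with a number 1 percentage points lower from compound 1 to compound 4 (within the scatter) and a number 7 percentage points lower from compound 2 to compound 4 (within the scatter), so the single gap beyond the scatter, between compound 2 and compound 3, does not carry over when bromo replaces fluoro. Nothing available accounts for these numbers or for their closeness.

On these data alone, whether any group at this position can lift the number clear of the floor remains open, for example an amine, a carboxylic acid or a longer chain on the aromatic carbon para to the large group. Also open, as far as these compounds go, is whether the shared core gives comparably low numbers in other cell lines.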